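Sulfonyl aryl exchange on the pyrrole sulfonamide series

The compounds below may be only part of what the source reports. "The series", "measured", "known", "first", "only" and "open" are said of these compounds alone.

Measured compounds:
compound 1 `CNCc1cc(-c2cccc(F)c2)n(S(=O)(=O)c2ccc(C)cc2)c1` — 77%
compound 2 `CNCc1cc(-c2ccc(F)cc2)n(S(=O)(=O)c2ccc(C)cc2)c1` — 86%
compound 3 `CNCc1cc(-c2cccnc2F)n(S(=O)(=O)c2cccc(C#N)c2)c1` — 99%

In a functional assay on the whole organism (strain Jcl:SD) for inhibition, with Rattus norvegicus as the target, with stated times of 3 min and 3 h, at a dose of 1 mg/kg by the intravenous route (a higher number here means more inhibition at the dose given (going by the name of the read-out), a lower number less inhibition), compound 3 gives 99%, the highest of the three values; the gaps to compound 2 and compound 1 both lie beyond the scatter. Among the measured compounds shown here, the one measured step at another position, a number 9 percentage points higher from compound 1 to compound 2 (within the scatter), is within the scatter. Compound 4 `CNCc1cc(-c2cccnc2F)n(S(=O)(=O)c2ccccn2)c1` differs from compound 3 by pyridin-2-yl in place of 3-cyanophenyl on a sulfonyl sulfur. For the measured compounds named here, no measured step touches the group on the sulfonyl sulfur, so nothing here sizes the change. Compound 3 sits close to the ceiling of the read-out, leaving little room upward. Compound 4 is therefore expected to give roughly 90%, in the range 70% to 100%, with the estimated step of a number 9 percentage points lower from compound 3 to compound 4 (within the scatter) left open in sign.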

Compound 4, a percentage reported as inhibition, in the whole organism at one dose (the size of the read-out at that dose, not a potency): 81%
For compound 4 the middle estimate is 9 percentage points above the measured one; the range from low to high includes it.
By their numbers in this assay, from the lowest: compounds 1, 4 and 2 (each within the scatter of the next); then compound 3.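

Among the compounds shown here, at the sulfonyl sulfur, the exchange of 3-cyanophenyl for pyridin-2-yl gives the first measured step at this position: in this assay, the change reads a number 18 percentage points lower from compound 3 to compound 4 (beyond the scatter) and sets compound 3 apart from compound 4. The group on the sulfonyl sulfur can therefore move this read-out, even at one dose and with one pair. Nothing on hand accounts for the step.

Open, as far as these compounds go, is whether the nitrile or the aromatic ring carries the step; a plain phenyl on the sulfonyl sulfur, with the rest of compound 3 kept, would separate the two. From the compounds shown here alone, whether the step holds with other groups on the shared core also remains open.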